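Methyl Ketone to Methyl Ester on a Shared Core

The source may report more compounds than this note shows. Statements on the series, on what has been measured and on what is new or still open speak of the compounds shown alone.

Compound 1 `CC1(C)S[C@@H]2/C(=C\C(=O)OC(c3ccccc3)c3ccccc3)C(=O)N2[C@H]1C(=O)OC(c1ccccc1)c1ccccc1`, compound 2 `CC(=O)/C=C1/C(=O)N2[C@@H]1SC(C)(C)[C@@H]2C(=O)OC(c1ccccc1)c1ccccc1` and compound 3 `CC1(C)[C@H](C(=O)OC(c2ccccc2)c2ccccc2)N2C(=O)/C(=C/C(=O)c3ccccc3)[C@H]2[S+]1[O-]` share one core and were tested in a functional assay on A-375 cells (Homo sapiens) for cytotoxicity, read by MTT assay, with a stated time of 48 h; on this read-out lower numbers stand for stronger inhibition and higher numbers for weaker inhibition. Compound 1 gives 9100 nM and compound 3 gives 4500 nM, while compound 2 gives 63000 nM, the highest number of the three and beyond the scatter from both others. Compound 4 `COC(=O)/C=C1/C(=O)N2[C@@H]1SC(C)(C)[C@@H]2C(=O)OC(c1ccccc1)c1ccccc1` has not yet been tested. It differs from compound 2 in one place: methoxy in place of methyl on a carbonyl carbon. For the measured compounds named here, no tested pair differs in only this way, so no measured step guides the expectation. Because compound 1, which carries an ester at the same place, gives 9100 nM, a lower number than compound 2, compound 4 is expected to show a modest step of a 2.1-fold lower number from compound 2 to compound 4 (0.32 log units; beyond the scatter). Compound 4 is estimated at 30000 nM, within 8000 nM to 100000 nM.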

Compound 4, half-maximal inhibitory concentration: 24600 nM
Compound 4: middle estimate off by 1.2-fold (0.09 log units), on the high side; low and high end bracket the measured number.
By their numbers in this assay, from the lowest: compound 3; then compound 1; then compound 4; then compound 2.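

In this assay, replacing methyl with methoxy on a carbonyl carbon, which turns acetyl into methoxycarbonyl, gives a 2.6-fold lower number from compound 2 to compound 4 (0.41 log units; beyond the scatter). For the compounds shown here, this is the first measured step for this change, and it shows that the number responds to what is attached at this carbonyl carbon, though only modestly. Nothing available explains the step.

Still open, going by these compounds, is how a carboxylic acid, an ethyl ester or a primary amide at this carbonyl carbon would compare with compound 4. Whether the same change gives a similar step with other groups elsewhere on the shared core is also unknown.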